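The source may report more compounds than this note shows. Statements on the series, on what has been measured and on what is new or still open speak of the compounds shown alone.

Measured compounds:
compound 1, `Cc1cc(=O)n(-c2ccc(Br)cc2F)nc1C(=O)Nc1ccc(Oc2ncnc3ccsc23)cc1`, a functional assay on HepG2 cells (Homo sapiens) for cytotoxicity, read by MTT assay, with a stated time of 72 h; a lower number here means a stronger inhibitor, a higher number a weaker inhibitor: 10600 nM
compound 2, `Cc1cc(=O)n(-c2ccccc2OC(F)(F)F)nc1C(=O)Nc1ccc(Oc2ncnc3ccsc23)cc1`, this assay: 25000 nM
compound 3, `Cc1ccc(-n2nc(C(=O)Nc3ccc(Oc4ncnc5ccsc45)cc3)c(C)cc2=O)cc1`, this assay: 25000 nM

Compound 3 stands level with compound 2 at the digits shown; together the two give the highest numbers of the three, while compound 1 gives a lower one, a 2.4-fold higher number from compound 1 to compound 3 (0.37 log units; beyond the scatter). For the measured compounds named here, all variation so far sits in the aryl group on the aromatic nitrogen of the shared core.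

Compound 4, `Cc1cc(=O)n(-c2ccc(F)cc2)nc1C(=O)Nc1ccc(Oc2ncnc3ccsc23)cc1`, continues that series: fluoro in place of methyl on an aromatic carbon. Going by the values given here, two measured steps bear on it. a 2.4-fold higher number from compound 1 to compound 3 (0.37 log units; beyond the scatter) was modest, from the 4-bromo-2-fluorophenyl compound to the 4-methylphenyl compound; no change at the digits printed from compound 2 to compound 3 (within the scatter) stayed within the scatter. Compound 4 keeps a single fluoro on the same aryl, so it sits between the 4-bromo-2-fluorophenyl of compound 1 and the 4-methylphenyl of compound 3. A step no larger than the modest one seen is therefore expected, if anything towards a lower number. In this assay compound 4 is expected near 18000 nM, with a range of 8000 nM to 40000 nM. The expected step is a 1.4-fold lower number from compound 3 to compound 4 (0.14 log units; within the scatter).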

Compound 4, half-maximal inhibitory concentration: 2110 nM
For compound 4 the middle estimate is 8.5-fold (0.93 log units) above the measured one; the whole stated range lies above it.
By their numbers in this assay, from the lowest: compound 4; then compound 1; then compounds 2 and 3 (each within the scatter of the next).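

In this assay, for the compounds shown here, fluoro in place of methyl on an aromatic carbon, para to a large group, gives a 12-fold lower number from compound 3 to compound 4 (1.07 log units; beyond the scatter), so this single replacement moves the number far more than any step among the earlier compounds. The 4-fluorophenyl group also stands clear of the 2-(trifluoromethoxy)phenyl group, with a 12-fold lower number from compound 2 to compound 4 (1.07 log units; beyond the scatter), and of the 4-bromo-2-fluorophenyl group, with a 5.0-fold lower number from compound 1 to compound 4 (0.70 log units; beyond the scatter), making compound 4 the strongest inhibitor of the four. A halogen on the aryl group therefore does not by itself give the low number, since compound 1 also carries halogens, though its bromo and second fluoro cannot be separated here.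

Nothing available explains the size of this step. Going by these compounds, how chloro, methoxy or an amine would read at this same position remains open.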